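Swapping the Amine Substituent on a Shared Core

This account rests on a few compounds, and the source may have more. Where it says the series, first, only, none or still open, it means among the compounds named here.

Measured so far:
compound 1 `CC(C)(CO)NCc1nc2c(OCC3CCCCC3)cccc2[nH]1`: 27500 nM
compound 2 `OCC(NCc1nc2c(OCC3CCCCC3)cccc2[nH]1)c1ccccc1`: 20000 nM

Both compounds were tested in an assay on cells for inhibition of interleukin-5 receptor subunit alpha (Mus musculus), read by WST assay, with a stated time of 48 h, in the presence of a further agent that is not named here; a higher number here means a weaker inhibitor, a lower number a stronger inhibitor. Compound 2 holds the lowest of the two numbers; its nearest neighbour is compound 1, and the step between them, a 1.4-fold lower number from compound 1 to compound 2 (0.14 log units; within the scatter), lies within the scatter, so the two cannot be told apart. Compound 3 `COc1ccc(NCc2nc3c(OCC4CCCCC4)cccc3[nH]2)cc1` has not been measured yet. It differs from compound 2 by 4-methoxyphenyl in place of 2-hydroxy-1-phenylethyl on an amine nitrogen. Going by the values given here, the only measured step, a 1.4-fold lower number from compound 1 to compound 2 (0.14 log units; within the scatter), exchanged one hydroxy-bearing substituent on that amine nitrogen for another and produced no change beyond the scatter. Among the compounds with values here, no measured step removes the hydroxy group or puts an aromatic ring directly on the nitrogen, so the new change is untested. Within the data shown here, with that single step as the only guide, compound 3 is expected to stay near compound 2, at about 20000 nM (range 4000 nM to 80000 nM), an expected step of no change at the digits printed from compound 2 to compound 3 (within the scatter).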

Compound 3, half-maximal inhibitory concentration: > 30000 nM
Compound 3 ended at the assay's limit (the forecaster's own chance of this, stated with the estimate: 25%); middle value at least 1.5-fold (0.17 log units) away from the limit.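

Compound 3 is the only one of the three with an aromatic ring directly on the amine nitrogen and no hydrogen-bond donor in that substituent, and in this assay it stands at a limit of the assay, not at a number: the limit of > 30000 nM in this assay, at which 1 of the 3 values shown sits.

Set against the two hydroxy-bearing compounds, this reading gives an at least 1.5-fold higher number from compound 2 to compound 3 (0.17 log units; that floor lies within the scatter) and an at least 1.0-fold higher number from compound 1 to compound 3 (0.03 log units; that floor lies within the scatter); both are only floors, so the true size of each step is unknown. What the result adds is that 4-methoxyphenyl on this nitrogen gives no sign of a stronger inhibitor.

The hydroxy group left and the ring moved onto the nitrogen in one change, and the compounds shown do not separate the two. From the compounds shown here alone, whether an unsubstituted phenyl, a 2-hydroxyethyl chain or a carboxylic acid on this nitrogen would give a lower number remains open.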